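Ethoxy in Place of Isopropyl on a Fused Ring

The compounds below may be only part of what the source reports. "The series", "measured", "known", "first", "only" and "open" are said of these compounds alone.

Compound 2 `CC(C)c1ccc2cc(-c3cc(-c4cc(Cl)cc(Cl)c4)nn3[C@@H](C)c3ccc(C(=O)NCCC(=O)O)cc3)ccc2c1` is the stronger of two compounds tested in a functional assay on CHO cells for antagonist activity at Glucagon receptor (Homo sapiens), read by scintillation counting and cAMP accumulation, with a stated time of 30 min; a higher number here means a weaker inhibitor, a lower number a stronger inhibitor: compound 2 gives 13.3 nM, while compound 1 `CCCOc1ccc(-c2cc(-c3cc(Cl)cc(Cl)c3)nn2Cc2ccc(C(=O)NCCC(=O)O)cc2)cc1Cl` gives 101 nM, a gap beyond the usual scatter. Compound 3 `CCOc1ccc2cc(-c3cc(-c4cc(Cl)cc(Cl)c4)nn3[C@@H](C)c3ccc(C(=O)NCCC(=O)O)cc3)ccc2c1` keeps the core of compound 2 and alters a single group: ethoxy in place of isopropyl on an aromatic carbon. Among the measured compounds shown here, no measured pair shows this exact exchange, so the expectation rests on compound 2 alone. The exchange is modest, and only a small shift, toward a slightly weaker inhibitor, is expected, a 1.7-fold higher number from compound 2 to compound 3 (0.22 log units; within the scatter). Compound 3 is therefore estimated at 22 nM, within a range of 7 nM to 70 nM.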

Compound 3, half-maximal inhibitory concentration: 23.6 nM
Compound 3: middle estimate off by 1.1-fold (0.03 log units), on the low side; low and high end bracket the measured number.
By their numbers in this assay, from the lowest: compounds 2 and 3 (each within the scatter of the next); then compound 1.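

On this aromatic carbon, ethoxy in place of isopropyl gives a 1.8-fold higher number from compound 2 to compound 3 (0.25 log units; within the scatter), so this assay does not separate the two groups. Among the compounds shown here, the swap brings in an oxygen and a hydrogen-bond acceptor, yet the number stays within the scatter, which is the first direct reading of a change at this position. Nothing available here explains why the two groups read alike. From the compounds shown here alone, whether this position would accept something quite different, such as an amine or a longer butoxy chain, remains open. Two groups compared at one place cannot show how far this tolerance extends.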